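The source may hold more compounds than are shown below. What is called first, only, known or untested is meant among the compounds shown, and "the series" means these compounds.

Compound 3 `Cc1cc(CN(C)C(CC(=O)O)c2ccc(Cl)cc2)ccc1OCCn1c(=O)ccn(C)c1=O` gives 1300 nM in an assay on CHO cells for displacement of a labelled ligand from C-X-C chemokine receptor type 3 (Homo sapiens), with a stated time of 60 min (a higher number here means a weaker inhibitor, a lower number a stronger inhibitor), the highest of the three numbers in hand. Compound 1 `CCCN(Cc1ccc(OCCN2C(=O)CCC2=O)c(OC)c1)C(C(=O)O)c1ccc(Cl)cc1` gives 256 nM in this assay and compound 2 `Cc1cc(CN(CC2CC2)[C@@H](CC(=O)O)c2ccc(Cl)cc2)ccc1OCCN1C(=O)CCC1=O` gives 42 nM. Going by the values given here, both of these differ from compound 3 in more than one place, so their values show only that lower numbers have been reached by compounds carrying larger groups on the amine nitrogen, not how much any single change contributes.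

Compound 4 `Cc1cc(CN(C2CCC2)C(CC(=O)O)c2ccc(Cl)cc2)ccc1OCCn1c(=O)ccn(C)c1=O` has not yet been measured. It differs from compound 3 in one place: cyclobutyl in place of methyl on an amine nitrogen. Among the compounds with values here, no measured pair shows this exact exchange. Compound 1 gives 256 nM and compound 2 gives 42 nM with larger groups on that nitrogen. On that basis the step of a 4.3-fold lower number from compound 3 to compound 4 (0.64 log units; beyond the scatter) is expected to be a move to a lower number, beyond the usual scatter. Compound 4 is therefore estimated at 300 nM, with a range from 100 nM to 900 nM.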

Compound 4, half-maximal inhibitory concentration in the C-X-C chemokine receptor type 3 assay: 95 nM
Compound 4: the middle estimate sits 3.2-fold (0.50 log units) above what was measured; the measured number lies below the stated range.
By their numbers in the C-X-C chemokine receptor type 3 assay, from the lowest: compound 2; then compound 4; then compound 1; then compound 3.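

Cyclobutyl in place of methyl on the amine nitrogen, with the rest of the molecule unchanged, gives in the C-X-C chemokine receptor type 3 assay a 14-fold lower number from compound 3 to compound 4 (1.14 log units; beyond the scatter), with compound 3 at 1300 nM and compound 4 at 95 nM, so this one group has a large effect that compound 1 and compound 2, with their several differences, could not isolate. The same exchange gives in a physicochemical assay for solubility, at pH 1.1 (on this read-out higher numbers stand for higher solubility and lower numbers for lower solubility), no change at the digits printed from compound 3 to compound 4 (within the scatter), with compound 3 at 3000000 nM and compound 4 at 3000000 nM, so the change appears in only one of the two read-outs. Nothing available explains the size of the step.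

As far as these compounds go, whether a cyclopentyl or an isopropyl group on this nitrogen would give a number closer to that of compound 4 or to that of compound 3 remains open. Also open, from the compounds shown here alone, is whether the effect of this exchange would carry over to the cores of compound 1 and compound 2, which differ from compound 3 elsewhere too.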